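The compounds below may be only part of what the source reports. "The series", "measured", "known", "first", "only" and "open" are said of these compounds alone.

Of the compounds shown here, three have been measured in a functional assay on OE21 cells (Homo sapiens) for cytotoxicity, read by MTT assay, with a stated time of 72 h (on this read-out higher numbers stand for weaker inhibition and lower numbers for stronger inhibition), and only one of them gives a number. Compound 1 (`C=C(C)CCOc1c(OC)cc(/C=C/CO)cc1OC`) reads > 100000 nM, which is a limit of the assay and not a number. Compound 2 (`C=C(C)CCOc1ccc(C(=O)O)cc1OC`) also reads only a limit, > 100000 nM. Among the compounds with values here, compound 3 (`COc1cc(/C=C/C=O)ccc1OC/C=C(\C)CCC=C(C)C`) is the one compound with a measured number, 34000 nM. The standing of compound 1 is therefore (the limit of > 100000 nM in this assay, at which 2 of the 3 values shown sit), so its true position is not known.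

The next compound, compound 4 (`COc1cc(/C=C/CO)cc(OC)c1O`), comes from compound 1 by a single change: hydrogen in place of 3-methylbut-3-en-1-yl on an oxygen on an aromatic ring. Hydrogen takes the place of 3-methylbut-3-en-1-yl on an oxygen on an aromatic ring, so the (3-methylbut-3-en-1-yl)oxy group becomes hydroxy. Within the data shown here, no pair of measured compounds shows this change on its own, so the expectation has little to rest on beyond the limit of compound 1 at > 100000 nM. No step beyond the usual scatter is expected in this assay, in either direction, and compound 4 may well be reported only as a limit. The estimate amounts to an expected step that the limit leaves unreadable from compound 1 to compound 4. For compound 4 the expected value is 120000 nM, with an estimated range from 50000 nM to 300000 nM.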

Compound 4, half-maximal inhibitory concentration: 80000 nM
Estimate against measurement, compound 4: 1.5-fold (0.18 log units) above; measured number inside the range.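

In this assay, hydrogen in place of 3-methylbut-3-en-1-yl on an oxygen on an aromatic ring gives an at least 1.2-fold lower number from compound 1 to compound 4 (0.09 log units; that floor lies within the scatter). Within the data shown here, this is the first change that can be read as a step between two measured compounds. Compound 4, with hydroxy on this oxygen, gives a number, 80000 nM, without the 3-methylbut-3-en-1-yl group. Compound 1 reads > 100000 nM, which is a limit and not a number, so the printed floor is all that can be said of the step, and its true size stays unknown because the starting value is only a limit: the limit of > 100000 nM in this assay, at which 2 of the 4 values shown sit.

The compounds shown leave open whether the real step from the (3-methylbut-3-en-1-yl)oxy group to hydroxy lies beyond the usual scatter, since only its floor can be read. They also leave open how a benzyl group or a plain ethyl group on this same oxygen would read in this assay, and whether the same exchange would behave alike on a different core.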